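The source may hold more compounds than are shown below. What is called first, only, known or untested is meant among the compounds shown, and "the series" means these compounds.

Measured in an ADME assay on Vero cells (Chlorocebus sabaeus) for cytotoxicity, with a stated time of 7 days; a lower number here means that less compound is tolerated, a higher number that more compound is tolerated:
- Compound 1 `COc1ccc2[nH]c(C(=O)N3CC(=O)N(Cc4ccccc4)[C@@H](CN4CCCCC4)C3)cc2c1`: 76900 nM
- Compound 2 `COc1ccc2[nH]c(C(=O)N3CC(=O)N(Cc4ccccc4)[C@@H](CN4CCC(C)CC4)C3)cc2c1`: > 30000 nM (a limit, not a number)
- Compound 3 `COc1ccc2[nH]c(C(=O)N3CC(=O)N(Cc4ccccc4)[C@@H](Cc4ccccn4)C3)cc2c1`: > 30000 nM (a limit, not a number)

Compound 3 has no exact reading and stands only at a limit, > 30000 nM. This is the limit of > 30000 nM in this assay, at which 2 of the 3 values shown sit.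

The next compound to be measured is compound 4 `COc1ccc2[nH]c(C(=O)N3CC(=O)N(Cc4ccccc4)[C@@H](N4[C@H](C)CCC[C@@H]4C)C3)cc2c1`. In it, 2,6-dimethylpiperidin-1-yl replaces (pyridin-2-yl)methyl on a saturated ring carbon: 2,6-dimethylpiperidin-1-yl in place of (pyridin-2-yl)methyl on a saturated ring carbon.

Going by the values given here, three measured steps bear on this change, and none of them has a readable size. They are a step that the limit leaves unreadable from compound 1 to compound 2, a step that the limit leaves unreadable from compound 1 to compound 3 and a step that the two limits leave unreadable from compound 2 to compound 3. Among the compounds with values here, the only exact number comes from compound 1 at 76900 nM, which also carries a piperidine ring, as piperidin-1-yl on a chain. With so little to go on, no step beyond the scatter is expected in this assay, and no direction can be argued. The estimated change is a step that the limit leaves unreadable from compound 3 to compound 4. A reading that again gives only a limit would be no surprise.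

For compound 4 the estimate is 45000 nM, with an expected range from 18000 nM to 100000 nM.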

Compound 4, half-maximal cytotoxic concentration: 1400 nM
Compound 4: the middle estimate sits 32-fold (1.51 log units) above what was measured, and the stated range ends above it.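

In this assay, going by these compounds alone, the steps among compound 1, compound 2 and compound 3 cannot be read, so the earlier compounds gave no measure of how much this position matters. Compound 4 provides that measure: with 2,6-dimethylpiperidin-1-yl on the saturated ring carbon in place of (piperidin-1-yl)methyl, the result is a 55-fold lower number from compound 1 to compound 4 (1.74 log units; beyond the scatter), which shows that this assay does respond to a change at this position. The other two comparisons give an at least 21-fold lower number from compound 2 to compound 4 (1.33 log units; beyond the scatter) and an at least 21-fold lower number from compound 3 to compound 4 (1.33 log units; beyond the scatter), and these are minimum sizes only, because compound 2 and compound 3 are both recorded as limits rather than numbers: the limit of > 30000 nM in this assay, at which 2 of the 4 values shown sit.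

The change removes the chain carbon and adds two methyl groups with defined stereocentres at once, so it remains open which of these accounts for the drop, and plain piperidin-1-yl on the same ring carbon would help to separate them. As far as these compounds go, it is also open how a morpholin-4-yl group or an open-chain diethylamino group would behave at this position.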